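The source may report more compounds than this note shows. Statements on the series, on what has been measured and on what is new or still open speak of the compounds shown alone.

Measured in a functional assay on HCT-116 cells (Homo sapiens) for antiproliferative activity, read by MTT assay, with a stated time of 72 h; on this read-out lower numbers stand for stronger inhibition and higher numbers for weaker inhibition:
- compound 1 `COc1ccc(N2C(=O)COc3ccc(-c4cnc(Cl)c(NS(=O)(=O)c5ccc(F)cc5)c4)cc32)cc1`: 30100 nM
- compound 2 `COc1ncc(-c2ccc3c(c2)N(c2ccc(F)cc2)C(=O)CO3)cc1NS(=O)(=O)c1ccc(F)cc1`: > 40000 nM, a limit of the assay
- compound 3 `CC(C)N1C(=O)COc2ccc(-c3cnc(Cl)c(NS(=O)(=O)c4ccc(F)cc4)c3)cc21`: 18900 nM

Going by the values given here, compound 3 stands level with compound 1 within the scatter, as the one numerical comparison shows: a 1.6-fold lower number from compound 1 to compound 3 (0.20 log units; within the scatter). Compound 2 gives no number to set beside them.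

The next compound is compound 4 `O=C1COc2ccc(-c3cnc(Cl)c(NS(=O)(=O)c4ccc(F)cc4)c3)cc2N1c1ccc(F)cc1`, which has 4-fluorophenyl in place of isopropyl on an amide-type nitrogen in a ring. Among the compounds with values here, the only measured step at this nitrogen runs from 4-methoxyphenyl to isopropyl, and it is a 1.6-fold lower number from compound 1 to compound 3 (0.20 log units; within the scatter). Read in reverse, it suggests that putting an aromatic ring back at this position should change little in this assay. At most, a small drift towards a higher number could be expected. Compound 2 also carries 4-fluorophenyl on this nitrogen, and its > 40000 nM is a limit.

No change beyond the scatter is therefore expected, on the strength of a single step. The expected step is a 1.3-fold higher number from compound 3 to compound 4 (0.12 log units; within the scatter). For compound 4 the estimate is 25000 nM, with an expected range of 13000 nM to 40000 nM.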

Compound 4, half-maximal inhibitory concentration: 34200 nM
Compound 4: middle estimate off by 1.4-fold (0.14 log units), on the low side; the range from low to high includes it.
By their numbers in this assay, from the lowest: compounds 3, 1 and 4 (each within the scatter of the next). At a limit, above all of these: compound 2.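

In this assay, the amide-type nitrogen now has three groups to compare, and 4-fluorophenyl in place of isopropyl on an amide-type nitrogen in a ring gives a 1.8-fold higher number from compound 3 to compound 4 (0.26 log units; within the scatter). The second comparison, fluoro in place of methoxy on an aromatic carbon of the aryl group at this nitrogen, gives a 1.1-fold higher number from compound 1 to compound 4 (0.06 log units; within the scatter), so neither change leaves the scatter and this set shows no separation between the alkyl group and either aryl group at this position. Compound 2 carries a limit: the limit of > 40000 nM in this assay, at which 1 of the 4 values shown sits. Chloro in place of methoxy on an aromatic carbon gives an at least 1.1-fold lower number from compound 2 to compound 4 (0.06 log units; that floor lies within the scatter), so this comparison provides only a floor.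

Compound 3 gives 18900 nM. On these data alone, whether a longer chain ending in an amine, or a carboxylic acid, on the amide-type nitrogen would move the number out of the scatter remains open. Also open, as far as these compounds go, is what a bromo or a nitrile would do on the aromatic carbon that carries chloro in compound 4, since only the methoxy comparison there is available and it ends at a limit.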